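The compounds below may be only part of what the source reports. "The series", "measured", "known", "first", "only" and "open" are said of these compounds alone.

Compound 2 `Cc1nc(Nc2ccccc2)sc1C(=O)/C=C/c1ccccc1` is one of three compounds tested in a functional assay on Bel-7402 cells (Homo sapiens) for cytotoxicity, read by MTT assay; on this read-out higher numbers stand for weaker inhibition and lower numbers for stronger inhibition. In this assay compound 2 gives > 25000 nM, which is a limit of the assay and not a measured number. Compound 3 `Cc1nc(Nc2ccccc2)sc1C(=O)/C=C/c1ccc(Cl)cc1`, which carries a chloro in place of hydrogen on an aromatic carbon, gives > 25000 nM in this assay, likewise a limit. Compound 1 `COc1cccc(/C=C/C(=O)c2sc(Nc3ccc(Cl)c(Cl)c3)nc2C)c1` gives > 25000 nM in this assay, once more a limit. Within the data shown here, the one directly comparable pair therefore yields a step that the two limits leave unreadable from compound 2 to compound 3, and due to the limit of > 25000 nM in this assay, at which 3 of the 3 values shown sit, the position of compound 2 relative to the others cannot be read in any direction.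

Compound 4 `Cc1nc(Nc2ccc(Cl)c(Cl)c2)sc1C(=O)/C=C/c1ccccc1` has not yet been measured. It differs from compound 2 by 3,4-dichlorophenyl in place of phenyl on a nitrogen on an aromatic ring. Compound 1 already carries a 3,4-dichlorophenyl on a nitrogen on an aromatic ring and still sits at the limit, so no step beyond the scatter is expected in this assay from this change. The step expected from this reasoning is a step that the limit leaves unreadable from compound 2 to compound 4, within the scatter. Compound 4 is therefore estimated at 50000 nM, with a range from 25000 nM to 150000 nM, and most likely the assay will again report only a limit for compound 4.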

Compound 4, half-maximal inhibitory concentration: 21500 nM
Beside the measured number, compound 4's estimate is 2.3-fold (0.37 log units) above it; measured number outside the range, below it.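

In this assay, the place on the nitrogen on an aromatic ring is the first in the compounds shown where a change leads from a limit to a measured number: 3,4-dichlorophenyl in place of phenyl gives an at least 1.1-fold lower number from compound 2 to compound 4 (0.06 log units; that floor lies within the scatter). The group does not bring this about alone, since compound 1 carries the same 3,4-dichlorophenyl and stays at the limit, so the methoxy on an aromatic carbon also counts here: hydrogen in place of methoxy gives an at least 1.1-fold lower number from compound 1 to compound 4 (0.06 log units; that floor lies within the scatter). Both steps are only floors that do not go beyond the usual scatter, so the real size of each stays unknown, and a real gain is possible but not shown, due to one feature of these data: the limit of > 25000 nM in this assay, at which 3 of the 4 values shown sit.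

The compounds shown leave open whether both chlorines are needed, or whether a single chloro on the phenyl would already give a measured number. They also leave open how an amine or a carboxylic acid on that same phenyl would read in this assay.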